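Caco-2 notes: tert-butyl to pyridylmethyl swap

The compounds below may be only part of what the source reports. "The series", "measured", "known", "first", "only" and "open" are said of these compounds alone.

Measured in an ADME assay on Caco-2 cells (Homo sapiens) for permeability, read by LC-MS, in the apical to basolateral direction, with a stated time of 60 min, at pH 6.5; on this read-out higher numbers stand for higher permeability and lower numbers for lower permeability:
- compound 1 `CC(C)(C)[C@@H](O)C(=O)N1[C@@H]2C[C@@H]2C[C@H]1C(=O)NCc1cc(Cl)ccc1-n1cnnn1`: 34 10^-6 cm/s
- compound 2 `CC(C)(C)[C@@H](O)C(=O)N1[C@H](C(=O)NCc2cc(Cl)ccc2-n2cnnn2)C[C@@H]2C[C@@H]21`: 16 10^-6 cm/s

Of the two measured compounds, compound 2 has the lower number at 16 10^-6 cm/s, and compound 1 is its nearest neighbour. Compound 3 `O=C(NCc1cc(Cl)ccc1-n1cnnn1)[C@@H]1C[C@@H]2C[C@@H]2N1C(=O)[C@H](O)Cc1ccccn1` departs from compound 2 by one change: (pyridin-2-yl)methyl in place of tert-butyl on a saturated chain carbon bound to a carbonyl carbon and an oxygen on a saturated carbon. Among the compounds with values here, the only measured step, a 2.1-fold lower number from compound 1 to compound 2 (0.33 log units; beyond the scatter), bears on this change only indirectly because of the fact that compounds 1 and 2 differ only in the configuration as drawn. Within the data shown here, no measured step touches the tert-butyl group, so the size of that step serves as a rough guide and the range is kept wide. A modest move to a lower number is expected in this assay, with the expected change being a 1.8-fold lower number from compound 2 to compound 3 (0.25 log units; within the scatter). For compound 3 the estimated value is 9 10^-6 cm/s, with an expected range of 3 10^-6 cm/s to 22 10^-6 cm/s.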

Compound 3, apparent permeability: 1.2 10^-6 cm/s
The estimate for compound 3 lay 7.5-fold (0.88 log units) above the measured number; measured number below the stated range.
By their numbers in this assay, from the lowest: compound 3; then compound 2; then compound 1.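

In this assay, (pyridin-2-yl)methyl in place of tert-butyl gives a 13-fold lower number from compound 2 to compound 3 (1.12 log units; beyond the scatter) as a large step, whereas the change of configuration alone gives a 2.1-fold lower number from compound 1 to compound 2 (0.33 log units; beyond the scatter) as a modest one. The read-out in this short series therefore depends far more on the group on the saturated chain carbon bound to a carbonyl carbon and an oxygen on a saturated carbon than on the two drawn stereocentres that separate compound 1 and compound 2. No measured property of either group accounts for the size of this step.

From the compounds shown here alone, whether the step follows from the pyridine nitrogen or from the aromatic ring as such remains open, and a benzyl group or an isopropyl group at this place would begin to separate these readings. Also open, going by these compounds, is whether the same swap on the configuration of compound 1 gives a step of similar size.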